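Naphthalen-2-yl for 4-fluorophenyl on the sulfonyl of compound 2

The compounds below may be only part of what the source reports. "The series", "measured", "known", "first", "only" and "open" are said of these compounds alone.

Compound 1 `COc1cc(C)c(Cl)cc1S(=O)(=O)n1c(C)c(/C=N/N2CCN(C)CC2)c2ccccc21` gives 2400 nM in a functional assay on HEK293 cells for antagonist activity at 5-hydroxytryptamine receptor 6 (Homo sapiens), read by cAMP accumulation, with stated times of 10 min and 1 h; on this read-out higher numbers stand for weaker inhibition and lower numbers for stronger inhibition.
Compound 2 `Cc1c(/C=N/N2CCN(C)CC2)c2ccccc2n1S(=O)(=O)c1ccc(F)cc1` gives 4740 nM in this assay.
Compound 3 `Cc1c(/C=N/N2CCN(C)CC2)c2ccccc2n1S(=O)(=O)c1ccc2ccccc2c1` is not yet measured.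

Compound 2 holds the higher of the two numbers, though the step of a 2.0-fold higher number from compound 1 to compound 2 (0.30 log units; within the scatter) lies within the scatter. Compound 3 differs from compound 2 by naphthalen-2-yl in place of 4-fluorophenyl on a sulfonyl sulfur. Among the measured compounds shown here, the only measured step at that sulfonyl sulfur, a 2.0-fold higher number from compound 1 to compound 2 (0.30 log units; within the scatter), exchanged one aryl group for another without leaving the scatter, so no step beyond the scatter is expected for compound 3 in this assay. Compound 3 is therefore estimated at 3500 nM (range 800 nM to 15000 nM), an expected step of a 1.4-fold lower number from compound 2 to compound 3 (0.13 log units; within the scatter).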

Compound 3, half-maximal inhibitory concentration: 2040 nM
Compound 3: middle estimate off by 1.7-fold (0.23 log units), on the high side, and the stated range covers the measured number.
By their numbers in this assay, from the lowest: compounds 3, 1 and 2 (each within the scatter of the next, the first and the last beyond it).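

At the sulfonyl sulfur, an aryl exchange now produces a step beyond the scatter: naphthalen-2-yl in place of 4-fluorophenyl gives a 2.3-fold lower number from compound 2 to compound 3 (0.37 log units; beyond the scatter), though this step is modest. Set against the 5-chloro-2-methoxy-4-methylphenyl group, the same naphthalen-2-yl gives a 1.2-fold lower number from compound 1 to compound 3 (0.07 log units; within the scatter), so these two groups are not told apart at this position. Nothing available gives a cause for either step.

Going by these compounds, it remains open whether naphthalen-1-yl would match naphthalen-2-yl on the sulfonyl sulfur. Also open, on these data alone, is how a non-aromatic group such as cyclohexyl or an amine-bearing 4-aminophenyl would read there.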